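Aryl swap on the shared core: pyridinyl to methylpyrazolyl

The source may report more compounds than this note shows. Statements on the series, on what has been measured and on what is new or still open speak of the compounds shown alone.

Three compounds have numbers in an ADME assay on Huh-7 cells (Homo sapiens) for cytotoxicity, read by MTT assay, with a stated time of 48 h; on this read-out higher numbers stand for lower toxicity in this test and lower numbers for higher toxicity in this test. Compound 1 `CN(C)CCCCNC(=O)Nc1ccc(CN2N=C(c3ccc(F)cc3)C3C=CC=CC3C2=O)cc1` gives 46600 nM, compound 2 `CN(C)CCCCOC(=O)Nc1ccc(Cn2nc(-c3cncnc3)c3ccccc3c2=O)cc1` gives 65300 nM, and compound 3 `CN(C)CCCCOC(=O)Nc1ccc(Cn2nc(-c3ccncc3)c3ccccc3c2=O)cc1` gives 62700 nM. On the numbers shown compound 3 stands second highest of three, nearest to compound 2 and furthest from compound 1, both gaps within the scatter. For the measured compounds named here, the only step at the same aromatic carbon is a 1.0-fold lower number from compound 2 to compound 3 (0.02 log units; within the scatter), a ring swap that left the number unchanged. Compound 4 `CN(C)CCCCOC(=O)Nc1ccc(Cn2nc(-c3cnn(C)c3)c3ccccc3c2=O)cc1` differs from compound 3 by 1-methyl-1H-pyrazol-4-yl in place of pyridin-4-yl on an aromatic carbon. Because a 1.0-fold lower number from compound 2 to compound 3 (0.02 log units; within the scatter) stayed within the scatter, a further aryl swap at that carbon is expected to give no step beyond the scatter in this assay, estimated as a 1.0-fold lower number from compound 3 to compound 4 (0.02 log units; within the scatter). For compound 4 the estimate is 60000 nM, range 35000 nM to 100000 nM.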

Compound 4, half-maximal cytotoxic concentration: 55900 nM
The estimate for compound 4 lay 1.1-fold (0.03 log units) above the measured number; measured number inside the range.
By their numbers in this assay, from the lowest: compounds 1, 4, 3 and 2 (each within the scatter of the next).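

Going from a six-membered to a five-membered aromatic ring at this aromatic carbon stays within the scatter in this assay: 1-methyl-1H-pyrazol-4-yl gives a 1.1-fold lower number from compound 3 to compound 4 (0.05 log units; within the scatter) against pyridin-4-yl, and a 1.2-fold lower number from compound 2 to compound 4 (0.07 log units; within the scatter) against pyrimidin-5-yl . Compound 2, compound 3 and compound 4 therefore read alike here, with none of the three going against that. No measurement available accounts for this flat reading.

As far as these compounds go, whether an amine or a carboxylic acid at this carbon would step beyond the scatter stays open. So does whether these aryl groups differ in any read-out other than this cytotoxicity test.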